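The compounds below may be only part of what the source reports. "The series", "measured", "known", "first", "only" and "open" are said of these compounds alone.

Measured compounds in a functional assay on HeLa cells (Homo sapiens) for cytotoxicity, read by MTT assay, with a stated time of 24 h; on this read-out lower numbers stand for stronger inhibition and higher numbers for weaker inhibition:
Compound 1 `C=CC1=C(C(=O)NCCC)C(c2ccc(Cl)c(Cl)c2)OC1` gives > 100000 nM, which is a limit of the assay and not a number.
Compound 2 `C=CC1=C(C(=O)NCc2ccc(Cl)cc2)C(c2ccc(F)cc2)OC1` gives > 100000 nM, likewise a limit of the assay.
Compound 3 `C=CC1=C(C(=O)NC2CCCCC2)C(c2ccc(OC)c(OC)c2)OC1` gives 5540 nM.

Compound 2 stands only as a limit in this assay, so no number places it against the others; its value sits with compound 1 at the limit of > 100000 nM in this assay, at which 2 of the 3 values shown sit, while compound 3 alone gives a measured number. No pair of these compounds differs in a single place, so no single step has been measured.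

Compound 4 `C=CC1=C(C(=O)NCCCCC)C(c2ccc(F)cc2)OC1` has not yet been measured. It differs from compound 2 by butyl in place of 4-chlorophenyl on a saturated chain carbon bound to an amide-type nitrogen. The amide substituent becomes a plain chain, and the aryl group on the core stays the same as in compound 2.

Since compound 2 gives only a limit, the expected step from compound 2 to compound 4 can be stated only loosely: the estimate is a number no higher from compound 2 to compound 4 (the limit leaves the size open), no change beyond the scatter. Compound 4 is expected to give about 100000 nM in this assay, with a range from 20000 nM to 300000 nM, most likely again reported only as a limit.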

Compound 4, half-maximal inhibitory concentration: > 100000 nM
Compound 4 was reported as a limit; the forecaster's own chance of this, stated with the estimate: 70%; the middle value sits exactly at the limit.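

In this assay compound 4 gives > 100000 nM, which is a limit of the assay. Compound 2 also stands only as a limit, so no step can be read between compound 2 and compound 4. The compounds shown leave open what pentyl in place of 4-chlorobenzyl does to the value.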